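Aminophenyl to methylaminopropyl on a shared core

The compounds below may be only part of what the source reports. "The series", "measured", "known", "first", "only" and "open" are said of these compounds alone.

For the measured compounds named here, compound 1 `Nc1ccc(Nc2c(C(=O)NCc3ccc(F)cc3)nc(Br)c3cccnc23)cc1` is the only compound of the series with a number in hand: in a functional assay on SK-BR-3 cells (Homo sapiens) for cytotoxicity, read by MTT assay, with a stated time of 72 h (on this read-out lower numbers stand for stronger inhibition and higher numbers for weaker inhibition), compound 1 gives 4000 nM. Compound 2 `N[C@H]1CC[C@H](Nc2c(C(=O)NCc3ccccn3)nc(Br)c3cccnc23)CC1` has no result in this assay, its entry reading "not determined" (no result reported). Compound 3 `CNCCCNc1c(C(=O)NCc2ccc(F)cc2)nc(Br)c2cccnc12` carries one change against compound 1, (3-(methylamino)propyl in place of 4-aminophenyl on a nitrogen on an aromatic ring). Going by the values given here, no step between two measured compounds is available to guide the expectation. The step expected from this change is estimated as a 1.3-fold lower number from compound 1 to compound 3 (0.12 log units; within the scatter), a modest step towards stronger inhibition that is not expected to go clearly beyond the scatter. For compound 3 the expected value is 3000 nM, within 800 nM to 12000 nM.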

Compound 3, half-maximal inhibitory concentration: 1000 nM
For compound 3 the middle estimate is 3.0-fold (0.48 log units) above the measured one, and the stated range covers the measured number.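

In this assay, 3-(methylamino)propyl in place of 4-aminophenyl on a nitrogen on an aromatic ring gives a 4.0-fold lower number from compound 1 to compound 3 (0.60 log units; beyond the scatter). This position therefore does not depend on the six-membered aromatic ring of compound 1, and a chain with no ring is accepted on the shared core. Nothing at hand explains this step. The compounds shown leave open how a longer chain, or a dimethylamino group in place of the methylamino group, would read at this position.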